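The source may report more compounds than this note shows. Statements on the series, on what has been measured and on what is new or still open speak of the compounds shown alone.

Working notes on the series.

Compound 1, `COc1ccc(S(=O)(=O)n2ccc3cccc(-c4ccc(F)cc4)c32)cc1`, is the reference point. In a functional assay on HT-29 cells (Homo sapiens) for inhibition, with a stated time of 72 h (on this read-out lower numbers stand for stronger inhibition and higher numbers for weaker inhibition), compound 1 gives 196 nM. Within the data shown here, the only other measured member is compound 2, `COc1ccc(S(=O)(=O)N2CCc3cccc(-c4ccc(N)cc4)c32)cc1`, which in this assay gives 301 nM. Compound 1 carries the lower of the two numbers, but the two values sit within the usual scatter of each other, so nothing can be said of an order between them; compound 2 also differs from compound 1 in more than one place, so no single step can be read off from the pair.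

The next compound in line is compound 3, `COc1ccc(S(=O)(=O)n2ccc3cccc(-c4ccc(C#N)cc4)c32)cc1`. Its relation to compound 1 is a single change: cyano in place of fluoro on an aromatic carbon. The fluoro leaves and the cyano enters at the same aromatic carbon, the rest of the shared core is untouched. Among the measured compounds shown here, no measured pair in the set shows this exchange, so there is no step to lean on.

The expectation for this assay is a step from compound 1 to compound 3 of a 1.3-fold higher number from compound 1 to compound 3 (0.12 log units; within the scatter), that is, no movement beyond the scatter. Compound 3 is accordingly estimated at 260 nM, with a range from 100 nM to 700 nM.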

Compound 3, half-maximal inhibitory concentration: 164 nM
For compound 3 the middle estimate is 1.6-fold (0.20 log units) above the measured one; measured number inside the range.
By their numbers in this assay, from the lowest: compounds 3, 1 and 2 (each within the scatter of the next).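

In this assay, among these compounds, the exchange at the aromatic carbon para to a large group, 4-fluorophenyl to 4-cyanophenyl, gives a 1.2-fold lower number from compound 1 to compound 3 (0.08 log units; within the scatter) and provides the first step that can be read at a single place. At this position, therefore, cyano in place of fluoro leaves the read-out within the scatter, even though the entering group has 2 heavy atoms, a triple bond and 1 hydrogen-bond acceptor, against 1 heavy atom and 0 hydrogen-bond acceptors for the group that leaves. No measurement on these compounds speaks to what lies behind this result.

Among the compounds shown here, it remains open whether a larger or charged group at the same carbon, such as a carboxylic acid or a morpholine ring, would also stay within the scatter of compound 1, since fluoro and cyano are the only two groups compared here on this core. On these data alone, it is also open whether cyano in place of fluoro would read the same way on the core of compound 2, which differs from compound 1 in more than one place.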